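Swapping the sulfonamide chain of compound 1 for an aminoethyl chain

A few compounds are considered here, and "the series" means these few. Any claim that something is new, unique, unknown or untested is made for them only; others in the source may bear on it.

Measured compounds:
compound 1 `Cc1ccc(S(=O)(=O)N(C)CC(C)C)cc1C#Cc1cc(Cl)ccc1OCC(=O)O` with 4.2 nM
compound 2 `CS(=O)(=O)c1ccc(C#Cc2cc(Cl)ccc2OCC(=O)O)cc1` with 86 nM
compound 3 `CCCS(=O)(=O)c1cc(C#Cc2cc(Cl)ccc2OCC(=O)O)c(C)cc1NC(C)=O` with 1.3 nM

All three compounds share a core carrying an acid-bearing ether and a chloro-substituted ring joined through an alkyne to a second ring that bears a sulfur-containing group. In an assay on CHO cells for displacement of a labelled ligand from prostaglandin D2 receptor 2 (Homo sapiens), read by scintillation counting (on this read-out lower numbers stand for stronger inhibition and higher numbers for weaker inhibition), compound 1 gives 4.2 nM. Among the three numbers this is the second highest. The nearest is compound 3 with 1.3 nM, a lower number by a gap beyond the scatter; the furthest is compound 2 with 86 nM, a higher number well beyond the scatter. Among the compounds with values here, only the two values of each pair are known; no single-point step between them is described.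

Compound 4 `Cc1ccc(S(=O)(=O)N(C)CCN(C)C)cc1C#Cc1cc(Cl)ccc1OCC(=O)O` is not yet measured. It differs from compound 1 in one place: (dimethylamino)methyl in place of isopropyl on a saturated chain carbon bound to a sulfonamide nitrogen. The sulfonamide itself stays, as does everything else in the molecule.

Within the data shown here, no measured pair shows what such a change on the sulfonamide chain does here. With compound 1 at 4.2 nM as the only anchor, a small step in this assay toward a somewhat higher number is expected, though a result within the scatter would not be surprising. The value of compound 4 is estimated at 8 nM, with a range from 2 nM to 30 nM, meaning an expected step of a 1.9-fold higher number from compound 1 to compound 4 (0.28 log units; within the scatter).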

Compound 4, inhibition constant: 369 nM
Estimate against measurement, compound 4: 46-fold (1.66 log units) below; measured number above the stated range.
By their numbers in this assay, from the lowest: compound 3; then compound 1; then compound 2; then compound 4.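

In this assay, (dimethylamino)methyl in place of isopropyl on a saturated chain carbon bound to a sulfonamide nitrogen brings an 88-fold higher number from compound 1 to compound 4 (1.94 log units; beyond the scatter) and gives the series its first change made in one place only. The step shows that this chain is not a passive part of the molecule: the sulfonamide and the rest of the structure stay the same, the carbon count of the swapped group stays the same, and the entering group adds one nitrogen, counted as a hydrogen-bond acceptor, yet the number climbs far beyond the scatter. Nothing available explains why the change costs so much.

One step cannot separate the effect of the nitrogen from that of the dimethylamino group as a whole, and steps involving compound 2 or compound 3 cannot be read, as those compounds differ from the others in more than one place. A 2-methoxyethyl chain, with oxygen at the spot the nitrogen takes, or a longer chain ending in a primary amine or a carboxylic acid, would test how far the loss depends on the atom and on its distance from the sulfonamide.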